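Methoxy in place of cyano: what compound 4 may show

The source may hold more compounds than are shown below. What is called first, only, known or untested is meant among the compounds shown, and "the series" means these compounds.

Measured so far in a functional assay on BT-474 cells (Homo sapiens) for inhibition, read by MTT assay, with a stated time of 5 days; a higher number here means a weaker inhibitor, a lower number a stronger inhibitor

Compound 1 `Cc1cc(Nc2nc(NCc3ccccc3Cl)nc3[nH]ncc23)n[nH]1` gives 7160 nM
Compound 2 `Cc1cc(Nc2nc(NCc3ccc(Br)cc3)nc3[nH]ncc23)n[nH]1` gives 4110 nM
Compound 3 `Cc1cc(Nc2nc(NCc3ccc(C#N)cc3)nc3[nH]ncc23)n[nH]1` gives 12100 nM

Two steps fix where compound 3 stands. One is a 2.9-fold higher number from compound 2 to compound 3 (0.47 log units; beyond the scatter) and the other is a 1.7-fold higher number from compound 1 to compound 3 (0.23 log units; within the scatter) so only the first of these separates a pair of compounds beyond the scatter.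

Compound 4 `COc1ccc(CNc2nc(Nc3cc(C)[nH]n3)c3cn[nH]c3n2)cc1` departs from compound 3 through one change: methoxy in place of cyano on an aromatic carbon with methoxy in place of cyano on an aromatic carbon, so that 4-cyanophenyl becomes 4-methoxyphenyl. Within the data shown here, no measured compound carries methoxy, so the evidence is indirect. The closest step is the exchange of bromo for cyano on an aromatic carbon (a 2.9-fold higher number from compound 2 to compound 3 (0.47 log units; beyond the scatter)) which is modest. The change of the whole substituted ring gives a 1.7-fold lower number from compound 1 to compound 2 (0.24 log units; within the scatter) and stays within the scatter. Across these three compounds the steps are small, and none suggests a large move for a single exchange of this kind.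

A small shift toward a lower number is expected, namely a 1.7-fold lower number from compound 3 to compound 4 (0.24 log units; within the scatter) and no large departure is anticipated. In this assay compound 4 is estimated at 7000 nM (expected range 3000 nM to 15000 nM) pending its measurement.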

Compound 4, half-maximal inhibitory concentration: 8230 nM
The estimate for compound 4 lay 1.2-fold (0.07 log units) below the measured number, and the stated range covers the measured number.
By their numbers in this assay, from the lowest: compounds 2, 1, 4 and 3 (each within the scatter of the next, the first and the last beyond it).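

In this assay, methoxy in place of cyano on the aromatic carbon gives a 1.5-fold lower number from compound 3 to compound 4 (0.17 log units; within the scatter), so this exchange does not separate the two compounds. Methoxy is also not separated from bromo at this place, with a 2.0-fold higher number from compound 2 to compound 4 (0.30 log units; within the scatter), and the change of the whole substituted ring to 4-methoxyphenyl from the 2-chlorophenyl of compound 1 gives a 1.1-fold higher number from compound 1 to compound 4 (0.06 log units; within the scatter). Among these compounds, three different groups have now been compared on this aromatic carbon, and the step from bromo to cyano remains the only one among the four compounds that lies beyond the scatter, while compound 4 lies within the scatter of each of the other three; no measurement is available to explain any of these numbers.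

The compounds shown leave open whether an amine or a carboxylic acid on this aromatic carbon, or a longer chain on its oxygen in place of the methyl of methoxy, would move the number beyond the scatter from compound 4. They also leave open how far the number can move at all through this substituted ring, since every compound shown keeps the same shared core.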